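Adding a methoxy to the dimethoxyphenyl chalcone-pyrazole

A few compounds are considered here, and "the series" means these few. Any claim that something is new, unique, unknown or untested is made for them only; others in the source may bear on it.

Compound 3 `COc1ccc(C(=O)/C=C/c2cc(-c3cc(OC)c(OC)c(OC)c3)n[nH]2)cc1OC` gives -99% in a functional assay on TK-10 cells (Homo sapiens) for cytotoxicity, read by sulforhodamine B assay, with a stated time of 48 h, tested at 100 uM (a lower number here means a stronger effect, a higher number a weaker effect of the compound at the concentration tested), the lowest of the three numbers. Compound 2 `COc1ccc(-c2cc(/C=C/C(=O)c3cc(OC)c(OC)c(OC)c3)[nH]n2)cc1OC` gives -94%, within the scatter of compound 3, while compound 1 `COc1cc(-c2cc(/C=C/C(=O)c3ccc(N)cc3)[nH]n2)cc(OC)c1OC` gives -81%; the step of a number 18 percentage points lower from compound 1 to compound 3 (beyond the scatter) is beyond the scatter. Compound 4 `COc1cc(C(=O)/C=C/c2cc(-c3cc(OC)c(OC)c(OC)c3)n[nH]2)cc(OC)c1OC` differs from compound 3 by methoxy in place of hydrogen on an aromatic carbon. Within the data shown here, no measured step matches this change, and compound 2 carries the trimethoxy group on the carbonyl side but with a different partner, so its value can only be compared directly: it lies within the scatter of compound 3. Compound 3 already sits near the floor of this read-out, so the step of a number 3 percentage points higher from compound 3 to compound 4 (within the scatter) is expected to stay within the scatter. Compound 4 is therefore estimated at -96%, between -105% and -82%.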

Compound 4, a percentage reported as activity, at one concentration (the size of the read-out at that concentration, not a potency): -99%
Compound 4: the middle estimate sits 3 percentage points above what was measured; the measured number falls inside the stated range.
By their numbers in this assay, from the lowest: compounds 3, 4 and 2 (each within the scatter of the next); then compound 1.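

The same change, methoxy in place of hydrogen on an aromatic carbon, can now be read on both aryl rings. In this assay it gives no change at the digits printed from compound 3 to compound 4 (within the scatter) on the carbonyl side and a number 5 percentage points lower from compound 2 to compound 4 (within the scatter) on the other ring. Neither ring therefore separates the added methoxy from hydrogen at this single concentration.

From the compounds shown here alone, it remains open whether an amine or a hydroxyl in place of a methoxy on either ring of compound 4 would shift this number, and whether lower concentrations would separate these compounds. No measurement shown here explains the result.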